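Restoring a Substituent on the Pendant Phenyl Ring

The source may report more compounds than this note shows. Statements on the series, on what has been measured and on what is new or still open speak of the compounds shown alone.

Compound 2 `COc1cc(-n2ncnc2-c2ccccc2)cc(OC)c1OC` stands at the floor of the numbers shown: in a functional assay on Jurkat cells (Homo sapiens) for antiproliferative activity, read by MTT assay, with a stated time of 72 h (on this read-out lower numbers stand for stronger inhibition and higher numbers for weaker inhibition), compound 2 gives > 10000 nM, which is a limit of the assay and not a number. Compound 1 `COc1cc(-n2ncnc2-c2ccc(C)cc2)cc(OC)c1OC` gives 300 nM. Compound 3 `COc1cc(-n2ncnc2-c2cccc(Cl)c2)cc(OC)c1OC` gives > 10000 nM, again a limit rather than a number. The change to compound 4 `CCOc1ccc(-c2ncnn2-c2cc(OC)c(OC)c(OC)c2)cc1` is ethoxy in place of hydrogen on an aromatic carbon, on an aromatic carbon of a six-membered aromatic ring of carbon only, the ring on which compound 1 carries its methyl. The step of an at least 33-fold higher number from compound 1 to compound 2 (1.52 log units; beyond the scatter) shows how much removing that methyl cost, and the limit of > 10000 nM in this assay, at which 2 of the 3 values shown sit, marks where compound 2 and compound 3 sit. An entering ethoxy is therefore expected to move the number strongly downward, an at least 6.6-fold lower number from compound 2 to compound 4 (0.82 log units; beyond the scatter). Compound 4 is estimated at 1500 nM, between 300 nM and 8000 nM.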

Compound 4, half-maximal inhibitory concentration: 5 nM
Beside the measured number, compound 4's estimate is 300-fold (2.48 log units) above it; measured number below the stated range.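

Ethoxy on the position para to a large group gives an at least 2000-fold lower number from compound 2 to compound 4 (3.30 log units; beyond the scatter), and this step is only a bound, set by a limit of the assay: the limit of > 10000 nM in this assay, at which 2 of the 4 values shown sit.

Set against methyl at the same place, ethoxy gives a 60-fold lower number from compound 1 to compound 4 (1.78 log units; beyond the scatter), so in this assay the gain seen with methyl is not the most this position allows, and the larger ethoxy group is accepted there.

Going by these compounds, whether the oxygen or the chain carries this gain stays open. So does how a methoxy group, a longer alkoxy chain or an amine at this position would read.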